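Aryl swap on the ring nitrogen: outlook for compound 4

This account rests on a few compounds, and the source may have more. Where it says the series, first, only, none or still open, it means among the compounds named here.

Measured compounds:
Compound 1 `N#CC1=C(N)Oc2c(c3nc4ccccc4nc3c3ccccc23)C12C(=O)N(Cc1cnnn1-c1ccccc1Cl)c1ccccc12`; in a functional assay on HepG2 cells (Homo sapiens) for antiproliferative activity, read by MTT assay, with a stated time of 48 h (on this read-out higher numbers stand for weaker inhibition and lower numbers for stronger inhibition), compound 1 gives > 50000 nM, which is a limit of the assay.
Compound 2 `CC(=O)Nc1ccc(-n2nncc2CN2C(=O)C3(C(C#N)=C(N)Oc4c3c3nc5ccccc5nc3c3ccccc43)c3ccccc32)cc1`; in this assay compound 2 gives > 50000 nM, again a limit rather than a number.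
Compound 3 `N#CC1=C(N)Oc2c(c3nc4ccccc4nc3c3ccccc23)C12C(=O)N(Cc1cnnn1-c1cccc(S(N)(=O)=O)c1)c1ccccc12`; in this assay compound 3 gives 21500 nM.

Within the data shown here, compound 3 thus holds the only actual number in this set; the other two values sit at the limit (the limit of > 50000 nM in this assay, at which 2 of the 3 values shown sit). Compound 4 `Cc1ccc(-n2nncc2CN2C(=O)C3(C(C#N)=C(N)Oc4c3c3nc5ccccc5nc3c3ccccc43)c3ccccc32)cc1Cl` differs from compound 3 by 3-chloro-4-methylphenyl in place of 3-sulfamoylphenyl on an aromatic nitrogen.

Among the measured compounds shown here, the steps that bear on this change are those into compound 3 from the two limit compounds: an at least 2.3-fold lower number from compound 1 to compound 3 (0.36 log units; beyond the scatter) and an at least 2.3-fold lower number from compound 2 to compound 3 (0.36 log units; beyond the scatter). Both show that bringing in 3-sulfamoylphenyl lowers the number by at least a modest amount, so taking it out again and putting in 3-chloro-4-methylphenyl, a group with no hydrogen-bond donor or acceptor like the 2-chlorophenyl of compound 1, is expected to move the number back up. The step that the two limits leave unreadable from compound 1 to compound 2 is unreadable between two limits and adds nothing here.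

For compound 4 the expectation in this assay is a rise of about a 1.9-fold higher number from compound 3 to compound 4 (0.27 log units; within the scatter) relative to compound 3, most likely ending at or near the limit. The estimate for compound 4 is 40000 nM, with a range from 12000 nM to 150000 nM.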

Compound 4, half-maximal inhibitory concentration: > 50000 nM
Compound 4: no number, only a limit (the forecaster's own chance of this, stated with the estimate: 55%); middle value at least 1.2-fold (0.09 log units) from the limit.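

Compound 4 gives > 50000 nM in this assay, which is a limit of the assay and not a number. Putting 3-chloro-4-methylphenyl in place of 3-sulfamoylphenyl on the aromatic nitrogen gives an at least 2.3-fold higher number from compound 3 to compound 4 (0.36 log units; beyond the scatter), so the measurable value of compound 3 does not survive this swap, and the size of the step is known only as a minimum. Compound 3 remains the only compound in the set with a number, and 3-sulfamoylphenyl the only aryl group shown that gives one, while the rest of the set sits at one limit: the limit of > 50000 nM in this assay, at which 3 of the 4 values shown sit.

The steps from compound 1 and compound 2 to compound 4 join two limits and cannot be read, so the order among these three stays open. Also open, from the compounds shown here alone, is whether a phenyl ring carrying a carboxylic acid or an amine at this place would give a number, or whether the sulfamoyl group is needed.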